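The source may report more compounds than this note shows. Statements on the series, on what has been measured and on what is new or still open speak of the compounds shown alone.

In a functional assay on K562 cells (Homo sapiens) for cytotoxicity, read by trypan blue exclusion, with a stated time of 96 h (on this read-out lower numbers stand for stronger inhibition and higher numbers for weaker inhibition), three compounds built on one shared core have been measured. Compound 3 `COc1cc(OC)c(/C=C/S(=O)(=O)Nc2ccc(OC)c(NC(C(=O)O)c3ccccc3)c2)c(OC)c1` gives 300 nM, the middle of the three numbers, whereas compound 1 `COC(=O)C(Nc1cc(NS(=O)(=O)/C=C/c2c(OC)cc(OC)cc2OC)ccc1OC)c1ccc(Cl)cc1` gives 2500 nM and compound 2 `COc1cc(OC)c(/C=C/S(=O)(=O)Nc2ccc(OC)c(NC(C)(C)C(=O)O)c2)c(OC)c1` gives 5 nM. Compound 4 `COc1cc(OC)c(/C=C/S(=O)(=O)Nc2ccc(OC)c(NC(C(=O)O)c3ccc(Cl)cc3)c2)c(OC)c1` differs from compound 3 by a single change, (chloro in place of hydrogen on an aromatic carbon), with chloro in place of hydrogen on an aromatic carbon, so that carboxy(phenyl)methyl becomes carboxy(4-chlorophenyl)methyl.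

Among the compounds with values here, no measured step isolates this change. The closest is an 8.3-fold lower number from compound 1 to compound 3 (0.92 log units; beyond the scatter), but that step loses the same chloro while also exchanging methoxycarbonyl for carboxy, and the data cannot separate the two. Two further steps, a 500-fold lower number from compound 1 to compound 2 (2.70 log units; beyond the scatter) and a 60-fold higher number from compound 2 to compound 3 (1.78 log units; beyond the scatter), show that the group on this nitrogen can shift the number widely, yet each replaces far more than one atom. With no direct evidence on the chloro alone, the expected change is small and its direction is uncertain, an estimated 1.2-fold lower number from compound 3 to compound 4 (0.08 log units; within the scatter). Compound 4 is estimated at 250 nM, with an expected range from 70 nM to 900 nM.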

Compound 4, half-maximal inhibitory concentration: 15 nM
Beside the measured number, compound 4's estimate is 17-fold (1.22 log units) above it, outside the stated range (below it).
By their numbers in this assay, from the lowest: compound 2; then compound 4; then compound 3; then compound 1.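

In this assay, within the data shown here, chloro in place of hydrogen on the aromatic carbon is, taken alone, a large step (a 20-fold lower number from compound 3 to compound 4 (1.30 log units; beyond the scatter)), which the earlier compounds showed only mixed with a second change. That second change now stands alone as well, with carboxy in place of methoxycarbonyl while the chloro stays (a 170-fold lower number from compound 1 to compound 4 (2.22 log units; beyond the scatter)). With the chloro present, carboxy(4-chlorophenyl)methyl still differs from 1-carboxy-1-methylethyl beyond the scatter (a 3.0-fold higher number from compound 2 to compound 4 (0.48 log units; beyond the scatter)), and nothing given here accounts for any of these steps.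

The compounds shown leave open whether fluoro, bromo or methyl on that aromatic carbon would move the number as chloro does. They also leave open how an amide in place of the carboxy would read on the carboxy(4-chlorophenyl)methyl group.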